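This account rests on a few compounds, and the source may have more. Where it says the series, first, only, none or still open, it means among the compounds named here.

Compound 2 `COc1cc(-c2nn(-c3cccc(NC(=O)Nc4ccc(Cl)c(C(F)(F)F)c4)c3)cc2-c2ccncc2)ccc1Cl` and compound 3 `O=C(Nc1cccc(-n2cc(-c3ccncc3)c(-c3ccc(Cl)c(O)c3)n2)c1)Nc1ccc(Cl)c(C(F)(F)F)c1` share one core and differ only in a single group on the phenyl ring that hangs from it. Going by the values given here, in a functional assay on KM12 cells (Homo sapiens) for inhibition, read by sulforhodamine B assay, with a stated time of 48 h (on this read-out lower numbers stand for stronger inhibition of growth and higher numbers for weaker inhibition of growth), compound 2 gives 3920 nM, the only plain number among the values reported. The other reported value belongs to compound 1 `O=C(Nc1cccc(-n2cc(-c3ccncc3)c(-c3ccc(Cl)c(O)c3)n2)c1)Nc1cccc(C(F)(F)F)c1`, for which this assay records > 32500 nM, a limit of the assay and not a number. Among the compounds with values here, compound 1 also carries the hydroxy group, but it differs from compound 2 in a second place as well, so the two values only show where each compound sits and give no single step.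

The change from compound 2 to compound 3 is hydrogen in place of methyl on an oxygen on an aromatic ring. Within the data shown here, no measured pair isolates this change. Among the measured compounds shown here, compound 3 is expected to lose potency, with a step of a 3.6-fold higher number from compound 2 to compound 3 (0.55 log units; beyond the scatter), because the limit of > 32500 nM in this assay, at which 1 of the 2 values shown sits, shows the only hydroxy-bearing compound in the set reaching the limit of this assay. Compound 3 is therefore estimated at 14000 nM, within a range of 4000 nM to 40000 nM, with a real chance that only a limit is reported.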

Compound 3, concentration for total growth inhibition: 3510 nM
Compound 3: the middle estimate sits 4.0-fold (0.60 log units) above what was measured; measured number outside the range, below it.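

In this assay, the step from methoxy to hydroxy on the 4-chloro-3-methoxyphenyl group is a 1.1-fold lower number from compound 2 to compound 3 (0.05 log units; within the scatter), so at this position the two groups cannot be told apart in this read-out, and a hydroxy group on this ring does not by itself take a compound out of the measurable range. Going by these compounds alone, with the hydroxy group kept in both compounds, chloro in place of hydrogen on an aromatic carbon gives an at least 9.2-fold lower number from compound 1 to compound 3 (0.96 log units; beyond the scatter), which makes this single change, and not the hydroxy group, the one that separates compound 3 from compound 1. Compound 1 is the one compound held at a limit of the assay and not at a number: the limit of > 32500 nM in this assay, at which 1 of the 3 values shown sits.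

The compounds shown leave open whether other groups on that oxygen, such as an ethyl group or a longer chain, or an amine in place of the oxygen, would read the same as hydroxy and methoxy. Within the data shown here, the chloro step is also seen only with hydroxy present, so its size with methoxy in place of hydroxy remains unknown.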